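Extending the chain end of compound 1

The compounds below may be only part of what the source reports. "The series", "measured", "known", "first", "only" and "open" are said of these compounds alone.

Among the measured compounds shown here, in a functional assay on SK-MEL-5 cells (Homo sapiens) for antiproliferative activity (on this read-out higher numbers stand for weaker inhibition of growth and lower numbers for stronger inhibition of growth), compound 1 `COCCCCCCCCCCC/C=C1\CC(CO)(COC(=O)C(C)(C)C)OC1=O` gives 2.81 ug/mL, the only exact number so far. Compound 2 `CCCCCCCCC(O)CCCCCC/C=C1\CC(CO)(COC(=O)C(C)(C)C)OC1=O` gives > 10 ug/mL, and this value is a limit. Compound 3 `CC(C)(C)C(=O)OCCCCCCCCCCCCCCC/C=C1\CC(CO)(COC(=O)C(C)(C)C)OC1=O` is not yet measured, and its difference from compound 1 is 4-(((tert-butyl)carbonyl)oxy)butyl in place of methoxy on a saturated chain carbon, ten or more bonds along the chain from a double-bonded chain carbon. For the measured compounds named here, the one measured step that bears on it, an at least 3.5-fold higher number from compound 1 to compound 2 (0.55 log units; beyond the scatter), is likewise a change along the chain and lies beyond the scatter. A step in the same direction is therefore expected in this assay, toward weaker inhibition of growth. The expected step is a 2.1-fold higher number from compound 1 to compound 3 (0.33 log units; beyond the scatter). Compound 3 is estimated at 6 ug/mL, with an expected range of 2.5 ug/mL to 15 ug/mL.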

Compound 3, concentration for 50% growth inhibition: 3.46 ug/mL
Estimate against measurement, compound 3: 1.7-fold (0.24 log units) above; the range from low to high includes it.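

In this assay, 4-(((tert-butyl)carbonyl)oxy)butyl in place of methoxy on a saturated chain carbon, ten or more bonds along the chain from a double-bonded chain carbon, gives a 1.2-fold higher number from compound 1 to compound 3 (0.09 log units; within the scatter). This place in the series therefore accepts a much larger ester-bearing chain end with no change beyond the scatter, so not every change along the chain weakens growth inhibition. Compound 2 remains the one exception, and its value is a limit: the limit of > 10 ug/mL in this assay, at which 1 of the 3 values shown sits.

Going by these compounds, whether a carboxylic acid or an amine in place of methoxy would hold the number of compound 1 stays open.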